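The source may report more compounds than this note shows. Statements on the series, on what has been measured and on what is new or still open speak of the compounds shown alone.

Measured in a functional assay on PC-3 cells (Homo sapiens) for cytotoxicity, read by WST assay, with a stated time of 48 h; on this read-out lower numbers stand for stronger inhibition and higher numbers for weaker inhibition:
Compound 1 `COc1ccccc1N1CCN(CCCNC(=O)CCCc2c[nH]c3ccccc23)CC1`: > 100000 nM
Compound 2 `COc1ccccc1N1CCN(CCCNC(=O)c2cc3ccc(Br)cc3[nH]2)CC1`: 31200 nM

Compound 1 gives > 100000 nM, which is a limit of the assay, not a number. Within the data shown here, compound 2 gives 31200 nM, the only true number so far, so it has no second number to be ranked against.

Next in line is compound 3 `COc1ccccc1N1CCN(CCCNC(=O)c2cc3cc(Cl)ccc3[nH]2)CC1`, which keeps the rest of compound 2 and changes only the group on the carbonyl carbon: 5-chloro-1H-indol-2-yl in place of 6-bromo-1H-indol-2-yl on a carbonyl carbon. Among the measured compounds shown here, no measured pair shows what an exchange of this kind does in this assay. No step beyond the usual scatter is therefore expected, and no direction is favoured. For the measured compounds named here, the sole anchor is compound 2 at 31200 nM. The expected change is a 1.1-fold higher number from compound 2 to compound 3 (0.05 log units; within the scatter). For compound 3 the estimated value is 35000 nM, with an expected range of 14000 nM to 85000 nM.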

Compound 3, half-maximal inhibitory concentration: 36900 nM
Beside the measured number, compound 3's estimate is 1.1-fold (0.02 log units) below it; the measured number falls inside the stated range.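

In this assay, 5-chloro-1H-indol-2-yl in place of 6-bromo-1H-indol-2-yl on a carbonyl carbon gives a 1.2-fold higher number from compound 2 to compound 3 (0.07 log units; within the scatter), so compound 2 and compound 3 cannot be told apart. Among these compounds, this is the first pair that differs in one place, and it shows that this exchange, at this place, leaves the read-out within the scatter, though the halogen and its numbered place in the name differ together and the pair does not separate them. Compound 1 remains a limit and not a number, and one value of the series stands there: the limit of > 100000 nM in this assay, at which 1 of the 3 values shown sits.

Open, on these data alone, is whether 5-bromo-1H-indol-2-yl, 6-chloro-1H-indol-2-yl or the unsubstituted 1H-indol-2-yl would stand apart from these two. Also open, as far as these compounds go, is what an amine or a carboxylic acid in place of the halogen would give.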